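Trimming the ring: from cyclohexyl to methyl on the shared core

This account rests on a few compounds, and the source may have more. Where it says the series, first, only, none or still open, it means among the compounds named here.

Compound 1 `O=c1oc(NC2CCCCC2)nc2ccccc12` is the reference point here. It was measured in a physicochemical assay for lipophilicity (a lower number here means a more polar compound, a higher number a more lipophilic compound), where compound 1 gives 3.5. Two further compounds on the same core were measured in this assay. Compound 2 `CCOc1nc2cc(N)cc(CC)c2c(=O)o1` gives 2.7. Compound 3 `CCNc1ccc2c(=O)oc(NC(C)C)nc2c1` gives 2.4. Among these three numbers compound 1 stands highest; compound 2 lies nearest to it, and that gap is already beyond the scatter, while compound 3 lies furthest, also beyond the scatter. No two of these compounds differ in a single place, so their values are only compared, not read as steps.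

The unmeasured compound 4 `CNc1nc2ccccc2c(=O)o1` differs from compound 1 in one place (methyl in place of cyclohexyl on a nitrogen on an aromatic ring). Compound 4 has not yet been measured in this assay.

Since a ring of carbon leaves and a single carbon enters, a substantial drop in this assay is expected, well beyond the scatter, from compound 1 to compound 4, estimated as a number 2.00 log units lower from compound 1 to compound 4 (beyond the scatter). Against the reference value of compound 1 in this assay, compound 4 is expected to give about 1.5, with a likely range from 1 to 2.1.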

Compound 4, distribution coefficient: 1.7
The estimate for compound 4 lay 0.20 log units below the measured number, and the stated range covers the measured number.
By their numbers in this assay, from the lowest: compound 4; then compounds 3 and 2 (each within the scatter of the next); then compound 1.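

In this assay, for the compounds shown here, the change of cyclohexyl to methyl on a nitrogen on an aromatic ring gives a number 1.80 log units lower from compound 1 to compound 4 (beyond the scatter) and provides the first reading in this set of what a change at a single place does, since the earlier compounds could only be set side by side. It shows that this position is not a silent one in this assay: the number responds strongly to what sits on this nitrogen, even though the exchange involves only carbon groups, with a six-membered ring of carbon leaving and a single carbon entering, and with hydrogen-bond donors, hydrogen-bond acceptors and net charge all counted as zero on both sides. Nothing at hand gives a measured reason for the size of this step.

From the compounds shown here alone, how the number moves between these two extremes stays open, for instance with a longer chain such as n-butyl or a smaller ring such as cyclopentyl on this nitrogen, and the same holds for a chain ending in a hydroxyl group or an amine. Going by these compounds, whether the step keeps its size when other groups stand elsewhere on the shared core is also open.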